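Hydroxypiperidine isomer in the benzofuran cytotoxicity series

The source may hold more compounds than are shown below. What is called first, only, known or untested is meant among the compounds shown, and "the series" means these compounds.

Compound 3 `Oc1ccc2oc(Cc3ccccc3)cc2c1CN1CCCC(O)C1` gives 11000 nM in a functional assay on SQ20B cells (Homo sapiens) for cytotoxicity, read by MTT assay, with a stated time of 72 h; on this read-out lower numbers stand for stronger inhibition and higher numbers for weaker inhibition. Within the data shown here, on the numbers so far it stands lowest of three, but its step to compound 1 `CN(Cc1c(O)ccc2oc(Cc3ccccc3)cc12)C1CCCCC1`, which gives 12000 nM, is a 1.1-fold lower number from compound 1 to compound 3 (0.04 log units; within the scatter) and so tells nothing; only against compound 2 `CON(C)Cc1c(O)ccc2oc(Cc3ccccc3)cc12`, which gives 40000 nM, is the gap a 3.6-fold lower number from compound 2 to compound 3 (0.56 log units; beyond the scatter), a modest one. Among the measured compounds shown here, the unmeasured compound 4 `Oc1ccc2oc(Cc3ccccc3)cc2c1CN1CCC(O)CC1` differs from compound 3 by 4-hydroxypiperidin-1-yl in place of 3-hydroxypiperidin-1-yl on a saturated chain carbon bound to an aromatic carbon; the two have the same atoms, joined differently, and no measured pair isolates this move of the hydroxyl within the ring. What bears on it is that swapping the whole amine, from compound 1 to compound 3, gave a 1.1-fold lower number from compound 1 to compound 3 (0.04 log units; within the scatter), while the larger change from compound 2 to compound 3 gave a 3.6-fold lower number from compound 2 to compound 3 (0.56 log units; beyond the scatter). A smaller alteration that keeps the ring, the donor and the acceptors is therefore expected to leave this assay essentially unchanged, with no step beyond the scatter. Compound 4 is estimated at 11000 nM (range 5000 nM to 25000 nM), meaning an expected step of no change at the digits printed from compound 3 to compound 4 (within the scatter).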

Compound 4, half-maximal inhibitory concentration: 13000 nM
Compound 4: the middle estimate sits 1.2-fold (0.07 log units) below what was measured; low and high end bracket the measured number.
By their numbers in this assay, from the lowest: compounds 3, 1 and 4 (each within the scatter of the next); then compound 2.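

In this assay the move of the hydroxyl within the ring now has its own measured pair (a 1.2-fold higher number from compound 3 to compound 4 (0.07 log units; within the scatter)), so 4-hydroxypiperidin-1-yl and 3-hydroxypiperidin-1-yl cannot be told apart on this saturated chain carbon. The 4-hydroxypiperidin-1-yl group also cannot be told apart from cyclohexyl(methyl)amino (a 1.1-fold higher number from compound 1 to compound 4 (0.03 log units; within the scatter)), yet it stands clear of methoxy(methyl)amino (a 3.1-fold lower number from compound 2 to compound 4 (0.49 log units; beyond the scatter)), so compound 2 remains the weakest while compounds 1, 3 and 4 form one group. No measured evidence accounts for these numbers.

Open, on these data alone, is whether the hydroxyl counts at all, which plain piperidin-1-yl or morpholin-4-yl in the same place would test. Also open, as far as these compounds go, is whether a longer chain in place of the saturated chain carbon moves the number away from this group.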